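The source may report more compounds than this note shows. Statements on the series, on what has been measured and on what is new or still open speak of the compounds shown alone.

Compound 1 `COc1ccc(C(=O)OC2(C(=O)Nc3ccc([N+](=O)[O-])cc3)CCCCC2)cc1` stands second highest of the three numbers in a functional assay on MCF7 cells (Homo sapiens) for inhibition, read by MTT assay, with a stated time of 72 h (a lower number here means a stronger inhibitor, a higher number a weaker inhibitor), where compound 1 gives 41.2 nM. Compound 3 `CCC(=O)OC1(C(=O)Nc2ccc([N+](=O)[O-])cc2)CCCCC1` gives 14.1 nM in this assay, and compound 2 `O=C(OC1(C(=O)Nc2ccc([N+](=O)[O-])cc2)CCCCC1)c1ccccc1I` gives 619 nM. Compound 4 `O=C(OC1(C(=O)Nc2ccc([N+](=O)[O-])cc2)CCCCC1)C(O)c1ccccc1` differs from compound 1 by hydroxy(phenyl)methyl in place of 4-methoxyphenyl on a carbonyl carbon. The measured steps that bear on this change at the same carbonyl carbon are a 2.9-fold lower number from compound 1 to compound 3 (0.47 log units; beyond the scatter) and a 15-fold higher number from compound 1 to compound 2 (1.18 log units; beyond the scatter), with a 44-fold lower number from compound 2 to compound 3 (1.64 log units; beyond the scatter) spanning the two. Since hydroxy(phenyl)methyl resembles neither ethyl nor 2-iodophenyl closely, no clear direction follows, and a step within the scatter is expected for compound 4 a 1.4-fold lower number from compound 1 to compound 4 (0.14 log units; within the scatter). Compound 4 is therefore estimated in this assay at 30 nM, with a range from 10 nM to 100 nM.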

Compound 4, half-maximal inhibitory concentration: 5.01 nM
Compound 4: middle estimate off by 6.0-fold (0.78 log units), on the high side, and the stated range ends above it.
By their numbers in this assay, from the lowest: compound 4; then compound 3; then compound 1; then compound 2.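

In this assay, the step of an 8.2-fold lower number from compound 1 to compound 4 (0.92 log units; beyond the scatter) and the step of a 2.8-fold lower number from compound 3 to compound 4 (0.45 log units; beyond the scatter) show that a group carrying a phenyl ring on this carbonyl carbon can give a lower number than ethyl, which neither 4-methoxyphenyl nor 2-iodophenyl did. With the step of a 120-fold lower number from compound 2 to compound 4 (2.09 log units; beyond the scatter) as well, compound 4 is the strongest inhibitor of the four, and the range at this position now widens at its potent end. No evidence is available on why hydroxy(phenyl)methyl behaves this way. The compounds shown leave open whether the hydroxy or the phenyl ring matters more, which benzyl, or an amine in place of the hydroxy, would help to separate.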